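This account rests on a few compounds, and the source may have more. Where it says the series, first, only, none or still open, it means among the compounds named here.

Measured so far in a functional assay on A498 cells (Homo sapiens) for inhibition, read by sulforhodamine B assay, with a stated time of 48 h; on this read-out higher numbers stand for weaker inhibition of growth and lower numbers for stronger inhibition of growth:

Compound 1 `COc1cc(-c2nn(-c3cccc(NC(=O)c4cccc(C(F)(F)F)c4)c3)cc2-c2ccncc2)ccc1Cl` gives 2780 nM.
Compound 2 `O=C(Nc1cccc(-n2cc(-c3ccncc3)c(-c3ccc(Cl)c(O)c3)n2)c1)Nc1cc(C(F)(F)F)cc(C(F)(F)F)c1` gives 4330 nM.

Compound 1 has the lowest of the two numbers, but compound 2 sits within the usual scatter of it, so the two cannot be told apart on this read-out. Going by the values given here, no pair of compounds differing in just one place has been measured, so no step has yet been sized.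

Compound 3 `COc1cc(-c2nn(-c3cccc(NC(=O)Nc4ccc(Cl)c(Cl)c4)c3)cc2-c2ccncc2)ccc1Cl` has not yet been measured. It differs from compound 1 in one place: (3,4-dichlorophenyl)amino in place of 3-(trifluoromethyl)phenyl on a carbonyl carbon. Cut one bond further out, the change reads (3,4-dichlorophenyl)carbamoyl in place of (3-(trifluoromethyl)phenyl)carbonyl. Compound 2, which also carries a carbamoyl group there, gives 4330 nM, within the scatter of compound 1, so no step beyond the scatter is expected in this assay . The estimate for compound 3 is 3000 nM, between 1200 nM and 8000 nM, meaning an expected step of a 1.1-fold higher number from compound 1 to compound 3 (0.03 log units; within the scatter).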

Compound 3, concentration for total growth inhibition: 4590 nM
Estimate against measurement, compound 3: 1.5-fold (0.18 log units) below; the range from low to high includes it.
By their numbers in this assay, from the lowest: compounds 1, 2 and 3 (each within the scatter of the next).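

The step at this position in this assay is a 1.7-fold higher number from compound 1 to compound 3 (0.22 log units; within the scatter) when (3,4-dichlorophenyl)amino replaces 3-(trifluoromethyl)phenyl on the carbonyl carbon. Going by these compounds alone, this is the first step sized here, and it shows that the exchange, which adds a hydrogen-bond donor and swaps fluorine for chlorine on the aromatic ring, leaves the growth-inhibition number unresolved from that of compound 1. No measurement is available that would explain this result.

On these data alone, the change alters two things at once, the added amino link and the halogens on the ring, so the effect of each alone remains unknown. As far as these compounds go, it also remains open whether a group without an aromatic ring on that carbonyl carbon, such as a short alkyl chain or a morpholine, would produce a step beyond the scatter.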